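Replacing the 3,4-dimethylphenyl group of compound 2

A few compounds are considered here, and "the series" means these few. Any claim that something is new, unique, unknown or untested is made for them only; others in the source may bear on it.

Compound 2 (`Cc1ccc(NC(=O)NCCCCC(c2ccc(F)cc2)c2ccc(F)cc2)cc1C`) gives > 20000 nM in a functional assay on MDA-MB-231 cells (Homo sapiens) for cytotoxicity, read by MTT assay, with a stated time of 48 h (on this read-out higher numbers stand for weaker inhibition and lower numbers for stronger inhibition), and this is a limit of the assay, not a number. Compound 3 (`O=C(NCCCCC(c1ccc(F)cc1)c1ccc(F)cc1)Nc1ccc(Cl)cc1C(F)(F)F`) has 4-chloro-2-(trifluoromethyl)phenyl in place of 3,4-dimethylphenyl on an amide-type nitrogen. Compound 1 (`O=C(NCCCCC(c1ccc(F)cc1)c1ccc(F)cc1)Nc1ccc([N+](=O)[O-])c(Cl)c1`) gives 3470 nM in this assay and also carries chlorine on that ring. Among the compounds with values here, the one measured step is an at least 5.7-fold higher number from compound 1 to compound 2 (0.76 log units; beyond the scatter) and it lies beyond the scatter, so a move of similar size towards lower numbers is expected, namely an at least 3.3-fold lower number from compound 2 to compound 3 (0.52 log units; beyond the scatter) as an estimate. Compound 3 is therefore expected at 6000 nM with 1800 nM to 20000 nM as its estimated range.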

Compound 3, half-maximal inhibitory concentration: > 20000 nM
Compound 3: only a limit was reported; the forecaster's own chance of this, stated with the estimate: 25%; middle value at least 3.3-fold (0.52 log units) away from the limit.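

Chlorine on the ring is not enough at this position on the amide-type nitrogen: 4-chloro-2-(trifluoromethyl)phenyl in place of 3-chloro-4-nitrophenyl gives an at least 5.7-fold higher number from compound 1 to compound 3 (0.76 log units; beyond the scatter). In this assay compound 3 gives > 20000 nM, which is a limit of the assay and not a number. The step from compound 2 to compound 3 cannot be read, because both stop at the same limit: the limit of > 20000 nM in this assay, at which 2 of the 3 values shown sit.

On these data alone, it remains open how much the nitro group and the chlorine of compound 1 each contribute to its lower number. As far as these compounds go, it is also open whether a phenyl ring carrying an amine or a carboxylic acid would give a readable value.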